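Cytotoxicity notes on a sulfonylazetidine amide series

The source may hold more compounds than are shown below. What is called first, only, known or untested is meant among the compounds shown, and "the series" means these compounds.

Measured so far in an ADME assay on MCF-10A cells (Homo sapiens) for cytotoxicity, with a stated time of 72 h; on this read-out higher numbers stand for an effect only at larger amounts of compound and lower numbers for an effect already at smaller amounts:
- compound 1 `O=C1OCc2cc(N(Cc3ccc(C4CCCCC4)cn3)C(=O)[C@H]3CCN3S(=O)(=O)c3c(F)c(F)c(F)c(F)c3F)ccc21`: 4600 nM
- compound 2 `O=C([C@H]1CCN1S(=O)(=O)c1c(F)c(F)c(F)c(F)c1F)N(Cc1ccc(C2CCCCC2)cc1)c1ccc2c(=O)[nH]ccc2c1`: 5300 nM
- compound 3 `O=C([C@H]1CCN1S(=O)(=O)c1c(F)c(F)c(F)c(F)c1F)N(Cc1ccc(C2CCCCC2)cc1)c1ccc2c(=O)[nH]ncc2c1`: 4600 nM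

On the numbers shown, compound 1 stands level with compound 3 at the digits given, and the two together give the lowest numbers of the three; the gap to compound 2 is within the scatter, so no order among the three is claimed.

Among the measured compounds shown here, the only step measured between close pairs is a 1.2-fold lower number from compound 2 to compound 3 (0.06 log units; within the scatter), a swap of one aromatic hetero ring for another on the amide-type nitrogen, with no change beyond the scatter.

Compound 4 `O=C([C@H]1CCN1S(=O)(=O)c1c(F)c(F)c(F)c(F)c1F)N(Cc1ccc(C2CCCCC2)cn1)c1cc2[nH]ncc2cc1F` is not yet measured. It differs from compound 1 thus: a group of 10 heavy atoms (7 carbon, 2 nitrogen, 1 fluorine; one five-membered aromatic ring with 2 hetero atoms, one six-membered aromatic ring of carbon only) in place of a group of 10 heavy atoms (8 carbon, 2 oxygen; one five-membered non-aromatic ring with 1 hetero atom, one six-membered aromatic ring of carbon only), on an amide-type nitrogen. The measured step concerns a different kind of exchange on the same nitrogen, so it bears only loosely on this one; it shows that altering the aryl group on the amide-type nitrogen left this assay flat. Nothing in the data points in either direction, so the expected step is a 1.0-fold lower number from compound 1 to compound 4 (0.01 log units; within the scatter), none beyond the scatter. The estimate for compound 4 is 4500 nM, in the range 2000 nM to 10000 nM.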

Compound 4, half-maximal effective concentration: 4900 nM
Compound 4: the middle estimate sits 1.1-fold (0.04 log units) below what was measured; the range from low to high includes it.
By their numbers in this assay, from the lowest: compounds 1, 3, 4 and 2 (each within the scatter of the next).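

In this assay, placing 5-fluoro-1H-indazol-6-yl on the amide-type nitrogen, in place of a group with a five-membered non-aromatic ring, gives a 1.1-fold higher number from compound 1 to compound 4 (0.03 log units; within the scatter) and so no change beyond the scatter. The earlier step at this position exchanged one aromatic hetero ring for another, whereas this one also removes the non-aromatic ring and the double bond outside aromatic rings and brings in fluorine and a hydrogen-bond donor. The flat read-out therefore holds for a wider change at this position than the earlier step covered, and no measurement at hand bears on why it stays flat.

Going by these compounds, whether a carboxylic acid on the group at the amide-type nitrogen would move this read-out beyond the scatter stays open. On these data alone, the effect of an amine elsewhere on the shared core also stays open.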